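Pyridinyl substituent change from compound 2 to compound 4

The source may report more compounds than this note shows. Statements on the series, on what has been measured and on what is new or still open speak of the compounds shown alone.

In a physicochemical assay for solubility, using the shake flask method, measured as kinetic solubility, with a stated time of 20 h, at pH 2 (on this read-out higher numbers stand for higher solubility and lower numbers for lower solubility), compound 1 (`FC(F)(F)c1cccc(-c2nc3cnc(Nc4ccccn4)cc3[nH]2)c1`) gives 21000 nM and compound 2 (`COc1cccc(Nc2cc3[nH]c(-c4cccc(C(F)(F)F)c4)nc3cn2)n1`) gives 85000 nM, the higher of these two numbers, at a 4.0-fold higher number from compound 1 to compound 2 (0.61 log units; beyond the scatter). Compound 3 (`COc1ccc(Nc2cc3[nH]c(-c4cccc(C(F)(F)F)c4)nc3cn2)nc1`) returns only a limit, < 5000 nM.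

Compound 4 (`Fc1ccc(Nc2cc3[nH]c(-c4cccc(C(F)(F)F)c4)nc3cn2)nc1`) has 5-fluoropyridin-2-yl in place of the 6-methoxypyridin-2-yl of compound 2, on a nitrogen on an aromatic ring: 5-fluoropyridin-2-yl in place of 6-methoxypyridin-2-yl on a nitrogen on an aromatic ring. Among the compounds with values here, two measured steps bear on this change. The closest is the large at least 17-fold lower number from compound 2 to compound 3 (1.23 log units; beyond the scatter), with 5-methoxypyridin-2-yl entering, and an at least 4.2-fold lower number from compound 1 to compound 3 (0.62 log units; beyond the scatter) points the same way. Within the data shown here, no compound with 5-fluoropyridin-2-yl has been measured, so a sizeable move to a lower number is expected by analogy. The estimated step is a 9.4-fold lower number from compound 2 to compound 4 (0.98 log units; beyond the scatter). For compound 4 the estimate is 9000 nM, with an expected range of 3000 nM to 30000 nM.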

Compound 4, solubility: < 5000 nM
Compound 4 gave a limit, no number; the forecaster's own chance of this, stated with the estimate: 35%; middle value at least 1.8-fold (0.25 log units) away from the limit.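

In this assay, 5-fluoropyridin-2-yl in place of 6-methoxypyridin-2-yl on this nitrogen gives an at least 17-fold lower number from compound 2 to compound 4 (1.23 log units; beyond the scatter). Fluoro in place of hydrogen on an aromatic carbon gives an at least 4.2-fold lower number from compound 1 to compound 4 (0.62 log units; beyond the scatter), so a fall from the unsubstituted pyridine is not confined to 5-methoxypyridin-2-yl. The step between the fluoro and methoxy compounds cannot be read, as compound 3 and compound 4 both return limits: the limit of < 5000 nM in this assay, at which 2 of the 4 values shown sit.

As far as these compounds go, the actual numbers behind those limits remain open, so fluoro and methoxy at this place cannot be ranked. Also open, from the compounds shown here alone, is whether an amine or a carboxylic acid in place of the fluoro would return a number rather than a limit.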